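A few compounds are considered here, and "the series" means these few. Any claim that something is new, unique, unknown or untested is made for them only; others in the source may bear on it.

Measured so far in a functional assay on NCI-H508 cells (Homo sapiens) for antiproliferative activity, read by MTT assay, with a stated time of 72 h; on this read-out higher numbers stand for weaker inhibition and lower numbers for stronger inhibition:
compound 1 `COc1cccc(/C=C2\CCC/C(=C\c3cc(OC)c(OC)c(OC)c3)C2=O)c1OC`, 4800 nM
compound 2 `COc1cc(/C=C2\CCC/C(=C\c3ccc(O)c(O)c3)C2=O)cc(OC)c1OC`, 7000 nM
compound 3 `COc1cc(/C=C2\CCC/C(=C\c3ccccc3Br)C2=O)cc(OC)c1OC`, 2700 nM

Compound 2 holds the highest of the three numbers; compound 1 stays within the scatter of it (a 1.5-fold higher number from compound 1 to compound 2 (0.16 log units; within the scatter)), whereas compound 3 lies beyond it (a 2.6-fold lower number from compound 2 to compound 3 (0.41 log units; beyond the scatter), modest). Compound 4 `COc1cc(/C=C2\CCC/C(=C\c3cccc(O)c3)C2=O)cc(OC)c1OC` is not yet measured. It differs from compound 2 by hydrogen in place of hydroxy on an aromatic carbon. The steps that touch this aryl group all swap the whole group: a 1.8-fold lower number from compound 1 to compound 3 (0.25 log units; within the scatter) stays within the scatter, and only the swap to the bromophenyl passes beyond it. Among the measured compounds shown here, no step removes a single hydroxy on its own. For compound 4 a step of a 1.4-fold lower number from compound 2 to compound 4 (0.15 log units; within the scatter) is therefore expected, small and towards a lower number if any. Compound 4 is expected to give 5000 nM in this assay, range 2000 nM to 12000 nM.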

Compound 4, half-maximal inhibitory concentration: 5600 nM
Beside the measured number, compound 4's estimate is 1.1-fold (0.05 log units) below it; low and high end bracket the measured number.
By their numbers in this assay, from the lowest: compounds 3, 1, 4 and 2 (each within the scatter of the next, the first and the last beyond it).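

In this assay, among the compounds shown here, the step of a 1.3-fold lower number from compound 2 to compound 4 (0.10 log units; within the scatter) is the first to remove a single hydroxy on its own, and it leaves 3,4-dihydroxyphenyl and 3-hydroxyphenyl unresolved. The 3-hydroxyphenyl group also stays within the scatter of 2,3-dimethoxyphenyl, with a 1.2-fold higher number from compound 1 to compound 4 (0.07 log units; within the scatter), whereas a 2.1-fold higher number from compound 3 to compound 4 (0.32 log units; beyond the scatter) passes beyond it, though compound 3 and compound 1 remain within the scatter of each other. No evidence given here bears on these steps.

The role of the remaining hydroxy stays open: the compounds shown include no unsubstituted phenyl and no amine or carboxylic acid in its place.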